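The source may report more compounds than this note shows. Statements on the series, on what has been measured and on what is new or still open speak of the compounds shown alone.

Measured compounds in a physicochemical assay for lipophilicity; on this read-out higher numbers stand for higher lipophilicity and lower numbers for lower lipophilicity:

compound 1, `O=[N+]([O-])c1cc[n+]([O-])c2c([N+](=O)[O-])cccc12`, 0.76
compound 2, `O=[N+]([O-])c1ccc2c([N+](=O)[O-])cc[n+]([O-])c2c1`, 0.45
compound 3, `Cc1ccc2c([N+](=O)[O-])cc[n+]([O-])c2c1`, 1.49

Compound 2 and compound 3 differ in a single place:

methyl in place of nitro on an aromatic carbon

That change made a large step in this assay: a number 1.04 log units higher from compound 2 to compound 3 (beyond the scatter). Compound 1 has the same atoms as compound 2, joined differently; the difference between the two cores is not broken down here. Its value lies beyond the scatter above that of compound 2 and beyond the scatter below that of compound 3.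

Compound 4, `Cc1cccc2c([N+](=O)[O-])cc[n+]([O-])c12`, has not yet been measured in this assay. It differs from compound 1 in one place:

methyl in place of nitro on an aromatic carbon

Among the measured compounds shown here, this is the same kind of change as the one from compound 2 to compound 3, not the same: in compound 3 the methyl sits meta to a fused ring and para to a fused ring, whereas in compound 4 it sits ortho to a fused ring and meta to a fused ring.

For the measured compounds named here, the expectation for compound 4 rests on the single measured step of this kind, a number 1.04 log units higher from compound 2 to compound 3 (beyond the scatter). Compound 4 is expected to show a step of similar size, a number 0.99 log units higher from compound 1 to compound 4 (beyond the scatter). Compound 4 is therefore estimated at 1.75. Going by the values given here, the range for compound 4 is estimated to run from 1.35 to 2.15, the width reflecting that the place of the change is not identical and only one earlier step of this kind is known.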

Compound 4, partition coefficient: 1.48
The estimate for compound 4 lay 0.27 log units above the measured number; the measured number falls inside the stated range.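

In this assay, methyl in place of nitro on an aromatic carbon gave a number 0.72 log units higher from compound 1 to compound 4 (beyond the scatter), the same direction as a number 1.04 log units higher from compound 2 to compound 3 (beyond the scatter), so the direction of the change carried from one core to the other, with the first of these steps rated modest and the second large. Among the compounds shown here, this does not show a fixed increment for the change: there are only two such steps, and the place differs, with the methyl of compound 4 ortho to a fused ring and meta to a fused ring, and that of compound 3 meta to a fused ring and para to a fused ring, so the data cannot separate an effect of the core from an effect of the place. Nothing available here explains the rise in either pair or the difference in the size of the two steps.

The compounds shown leave open whether an ethyl group or a longer chain in place of nitro would follow the same direction on both cores. They also leave open how an amine or a carboxylic acid in place of nitro would behave on either core, and whether a third core would repeat the direction seen in these two pairs.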